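The source may hold more compounds than are shown below. What is called first, only, known or untested is meant among the compounds shown, and "the series" means these compounds.

Measured compounds:
compound 1, `CCc1ccc(C(=O)Nc2ccc3nc(N4CCN(CC)CC4)cc(C)c3c2)cc1`, 3060 nM
compound 2, `Cc1cc(N(C)C)nc2ccc(NC(=O)c3ccc(Cl)c(Cl)c3)cc12`, 33300 nM
compound 3, `CCN1CCN(c2cc(C)c3cc(NC(=O)c4ccc5ccccc5n4)ccc3n2)CC1`, 7060 nM

All three were tested in a functional assay on MCF7 cells (Homo sapiens) for antiproliferative activity, read by MTT assay, with a stated time of 72 h; a lower number here means a stronger inhibitor, a higher number a weaker inhibitor. Compound 1 gives the lowest number of the three; compound 3 comes nearest, and compound 2, which also carries a different amine on the shared core, lies furthest away. Within the data shown here, the one single-point step among the measured compounds, a 2.3-fold higher number from compound 1 to compound 3 (0.36 log units; beyond the scatter), shows that swapping the 4-ethylphenyl on the carbonyl carbon for another aryl group already moves the number upward by a modest amount.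

Compound 4, `CCN1CCN(c2cc(C)c3cc(NC(=O)c4ccccc4Cl)ccc3n2)CC1`, is the next step from compound 1: 2-chlorophenyl in place of 4-ethylphenyl on a carbonyl carbon. The group that enters is smaller and carries a chlorine instead of the ethyl chain. Among the measured compounds shown here, the step to compound 3 is the only direct guide, and it points to a weaker inhibitor when the 4-ethylphenyl leaves; the chlorinated aryl of compound 2 sits at the high end of the numbers, though its core also differs. A modest rise in the number is therefore expected, a 2.6-fold higher number from compound 1 to compound 4 (0.42 log units; beyond the scatter). Compound 4 is estimated at 8000 nM, within a range of 3000 nM to 25000 nM.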

Compound 4, half-maximal inhibitory concentration: > 50000 nM
Compound 4: no number, only a limit; the forecaster's own chance of this, stated with the estimate: 5%; middle value at least 6.2-fold (0.79 log units) from the limit.
By their numbers in this assay, from the lowest: compound 1; then compound 3; then compound 2. At a limit, above all of these: compound 4.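

The value for compound 4 is a limit of the assay and not a number: the limit of > 50000 nM in this assay, at which 1 of the 4 values shown sits. Even so, this place on the carbonyl carbon proves far more sensitive than the earlier step suggested, with a change of aryl group able to do more than shift the number modestly: the new step is large (an at least 16-fold higher number from compound 1 to compound 4 (1.21 log units; beyond the scatter)). The two replacements for 4-ethylphenyl also differ clearly from each other, with 2-chlorophenyl giving a weaker inhibitor than quinolin-2-yl (an at least 7.0-fold higher number from compound 3 to compound 4 (0.85 log units; beyond the scatter)).

The compounds shown cannot separate the loss of the ethyl chain from the arrival of the chlorine, and they do not show how far beyond its limit compound 4 lies. A plain phenyl, a longer alkyl chain or an amine on the same aryl ring would help to tell these apart.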